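Extending a Phenol in a Neuropeptide Y Receptor Series

The compounds below may be only part of what the source reports. "The series", "measured", "known", "first", "only" and "open" are said of these compounds alone.

Of the compounds shown here, two sharing a core have been measured so far. Compound 1 `Oc1cccc2c1nc(COc1ccc(Cl)cc1)n2CCCC1CCCNC1` gives 5300 nM in an assay on isolated protein for binding affinity to Neuropeptide Y receptor type 1 (Homo sapiens); a lower number here means a stronger inhibitor, a higher number a weaker inhibitor. Compound 2 `Clc1ccc(OCc2nc3ccccc3n2CCCC2CCNCC2)cc1` gives 980 nM in this assay; between these two values compound 1 stands as the higher, so the weaker, of the pair, by a margin beyond the usual scatter.

Compound 3 `Clc1ccc(OCc2nc3c(OCCCN4CCCCC4)cccc3n2CCCC2CCCNC2)cc1` has not yet been measured. It differs from compound 1 in one place: 3-(piperidin-1-yl)propyl in place of hydrogen on an oxygen on an aromatic ring. Measured neighbours that differ in only this way are absent, so the direction of the step cannot be read from the data. Given that the only other measured compound sits below compound 1, a move toward stronger binding is the expectation adopted here. The step is expected to be a 3.5-fold lower number from compound 1 to compound 3 (0.55 log units; beyond the scatter). Compound 3 is thus estimated at 1500 nM, with a range from 300 nM to 8000 nM.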

Compound 3, inhibition constant: 1.7 nM
For compound 3 the middle estimate is 880-fold (2.95 log units) above the measured one; the whole stated range lies above it.
By their numbers in this assay, from the lowest: compound 3; then compound 2; then compound 1.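

The oxygen on the aromatic ring proves to be a highly sensitive position in this assay: putting 3-(piperidin-1-yl)propyl in place of its hydrogen gives a 3100-fold lower number from compound 1 to compound 3 (3.49 log units; beyond the scatter). The earlier compounds shown here carried no group on such an oxygen, so they could not show that a change here might shift binding at all, let alone by a step this large. No measurement offered here explains the gain.

From the compounds shown here alone, it remains open whether the whole group is needed: a plain propyl on the same oxygen, with no amine, or a shorter ethyl chain ending in piperidine would separate the share of the ring from that of the chain. Whether a morpholine could replace the piperidine and keep this strength is also unanswered.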